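From trifluoromethyl to methoxy on a shared core

A few compounds are considered here, and "the series" means these few. Any claim that something is new, unique, unknown or untested is made for them only; others in the source may bear on it.

- compound 1 `CCNC(=O)Nc1sc2ccccc2c1C(=O)N1CCN(C2CCN(C(=O)C(C)C)CC2)CC1`: "not determined" (no result reported)
- compound 2 `CCNC(=O)Nc1sc2ccccc2c1C(=O)N1CCN(C2CCN(C(=O)C3CCCC3)CC2)CC1`: 309 nM
- compound 3 `CCNC(=O)Nc1sc2cc(C(F)(F)F)ccc2c1C(=O)N1CCN(C2CCN(C(=O)C(C)(C)C(F)(F)F)CC2)CC1`: "not determined" (no result reported)

In a functional assay on HepG2 cells (Homo sapiens) for inhibition, read by scintillation counting, with a stated time of 2 h (a higher number here means a weaker inhibitor, a lower number a stronger inhibitor), compound 3 has no number to stand on, its entry reading "not determined" (no result reported). The same holds for compound 1, at "not determined" (no result reported), so only compound 2 offers a number, 309 nM.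

The unmeasured compound 4 `CCNC(=O)Nc1sc2cc(OC)ccc2c1C(=O)N1CCN(C2CCN(C(=O)C(C)(C)C(F)(F)F)CC2)CC1` departs from compound 3 in one place. The change is methoxy in place of trifluoromethyl on an aromatic carbon.

Going by the values given here, without a starting number, no step of known size or direction can be expected in this assay, so the estimate leans on compound 2 at 309 nM, and it stays wide. For compound 4 the expected value is 200 nM, with an estimated range of 40 nM to 1000 nM.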

Compound 4, half-maximal inhibitory concentration: 67 nM
The estimate for compound 4 lay 3.0-fold (0.47 log units) above the measured number, and the stated range covers the measured number.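

Going by these compounds alone, compound 3 has no single number in this assay, so no step to compound 4 can be read. What methoxy in place of trifluoromethyl does to inhibition stays open, and no measured evidence explains the result for compound 4.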